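Swapping a Methoxy for a Phenyl Group

The source may report more compounds than this note shows. Statements on the series, on what has been measured and on what is new or still open speak of the compounds shown alone.

Measured in a functional assay on HepG2 cells (Homo sapiens) for antiproliferative activity, read by MTT assay, with a stated time of 48 h; on this read-out higher numbers stand for weaker inhibition and lower numbers for stronger inhibition:
compound 1 `CCOc1ccc(C(=O)/C=C/c2c(/C=C/c3ccc(OC)cc3)cc(OC)cc2OC)cc1`: 8 ug/mL
compound 2 `COc1ccc(/C=C/c2cc(OC)cc(OC)c2/C=C/C(=O)c2ccc(OC)cc2)cc1`: 4.9 ug/mL

Going by the values given here, compound 2 is one of only two measured compounds, and its 4.9 ug/mL cannot be told apart from the value of compound 1. Among the compounds with values here, the one measured step, a 1.6-fold lower number from compound 1 to compound 2 (0.21 log units; within the scatter), put hydrogen in place of methyl on a saturated chain carbon bound to an oxygen. Compound 3 `COc1ccc(/C=C/c2cc(OC)cc(OC)c2/C=C/C(=O)c2ccc(-c3ccccc3)cc2)cc1` carries a larger change, phenyl in place of methoxy on an aromatic carbon. That single small step gives no firm direction, so no shift beyond the scatter is expected in this assay. The expected result is a 1.2-fold higher number from compound 2 to compound 3 (0.09 log units; within the scatter). For compound 3 the estimated value is 6 ug/mL, with an expected range of 2.5 ug/mL to 14 ug/mL.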

Compound 3, half-maximal inhibitory concentration: 10.5 ug/mL
For compound 3 the middle estimate is 1.8-fold (0.24 log units) below the measured one; the range from low to high includes it.
By their numbers in this assay, from the lowest: compounds 2, 1 and 3 (each within the scatter of the next, the first and the last beyond it).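

In this assay, going by these compounds alone, this position, on an aromatic carbon para to a large group, now gives the first change beyond the scatter, though a modest one, when phenyl replaces methoxy: a 2.1-fold higher number from compound 2 to compound 3 (0.33 log units; beyond the scatter). Set against the ethoxy group, the same phenyl gives a difference within the scatter: a 1.3-fold higher number from compound 1 to compound 3 (0.12 log units; within the scatter). No measurement available here accounts for these results. Open, going by these compounds, is how an amine or a carboxylic acid would fare at this position, and whether a longer chain on the oxygen would move the number at all.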